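The compounds below may be only part of what the source reports. "The series", "measured", "known", "first", "only" and "open" are said of these compounds alone.

Two compounds have been measured in a functional assay for antagonist activity at melanin-concentrating hormone receptor 1 (Homo sapiens); on this read-out higher numbers stand for weaker inhibition and lower numbers for stronger inhibition:
compound 1 `CC(C)N(CCN(C(=O)Nc1cccc(Br)c1)C1CC[C@]2(c3cccc(C#N)c3)CC2C1)C(C)C` gives 5.7 nM;
compound 2 `CC(C)N(CCN(C(=O)Nc1cccc(Cl)c1)C1CC[C@]2(c3cccc(C#N)c3)CC2C1)C(C)C` gives 6 nM.

Within the data shown here, compound 2 stands at the higher of the two numbers, with compound 1 as its only neighbour, and the gap between them is within the scatter. The step of a 1.1-fold higher number from compound 1 to compound 2 (0.02 log units; within the scatter) shows that exchanging bromo for chloro on the aromatic carbon left the read-out essentially where it was. Compound 3 `CC(C)N(CCN(C(=O)Nc1cccc(C#N)c1)C1CC[C@]2(c3cccc(C#N)c3)CC2C1)C(C)C` changes the same group once more: cyano in place of chloro on an aromatic carbon. Among the measured compounds shown here, the only measured step that bears on this change is the bromo-to-chloro exchange, and it was flat. For the measured compounds named here, no measured compound carries a cyano group at this place, so that one flat step is only a loose guide, and a modest move in either direction would not be surprising. Going by the values given here, the expectation is a step of a 1.5-fold higher number from compound 2 to compound 3 (0.18 log units; within the scatter), with the width of the range reflecting how little the single comparison can tell. Compound 3 is estimated at 9 nM, within a range from 3 nM to 30 nM.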

Compound 3, inhibition constant: 7.6 nM
For compound 3 the middle estimate is 1.2-fold (0.07 log units) above the measured one; the measured number falls inside the stated range.
By their numbers in this assay, from the lowest: compounds 1, 2 and 3 (each within the scatter of the next).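

Moving from the two halogens to a cyano group is a larger change in make-up: two heavy atoms replace one, and the new group has a triple bond and a hydrogen-bond acceptor, which chloro lacks. Even so, this assay shows a 1.3-fold higher number from compound 2 to compound 3 (0.10 log units; within the scatter), and the comparison with bromo shows a 1.3-fold higher number from compound 1 to compound 3 (0.12 log units; within the scatter), so the flat read-out at this place, meta to a large group, is no longer confined to a swap of one halogen for another. All three groups now sit within the scatter of one another, but the numbers alone do not explain this flatness, and no supporting evidence bears on it.

Going by these compounds, it remains open whether the read-out would stay this flat with an amine, a carboxylic acid, a methoxy group or a longer chain at the same place, or with only a hydrogen there, which would show whether a group is needed at this place at all. On these data alone, it is also open whether the three groups would still match if the rest of the core of compound 1 were changed.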